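Methyl in Place of Cyano on a Thiophene Carbon

A few compounds are considered here, and "the series" means these few. Any claim that something is new, unique, unknown or untested is made for them only; others in the source may bear on it.

Measured compounds:
compound 1, `CC#C[C@@H](Cc1nnn[nH]1)c1ccc(OCc2ccc3sc(C#N)c(-c4ccccc4C)c3c2)cc1`: 16 nM
compound 2, `CC#C[C@@H](Cc1nnn[nH]1)c1ccc(OCc2ccc3sc(C(F)(F)F)c(-c4ccc(OCCOC)cc4C)c3c2)cc1`: 13 nM

In a functional assay on cells for agonist activity at Free fatty acid receptor 1 (Homo sapiens), read by FLIPR and calcium flux (on this read-out higher numbers stand for an effect only at larger amounts of compound and lower numbers for an effect already at smaller amounts), compound 1 gives 16 nM, the higher of the two numbers shown, while compound 2 gives 13 nM, a gap that falls within the scatter. Compound 3, `CC#C[C@@H](Cc1nnn[nH]1)c1ccc(OCc2ccc3sc(C)c(-c4ccccc4C)c3c2)cc1`, has not been measured. It differs from compound 1 in one place: methyl in place of cyano on an aromatic carbon. Among the measured compounds shown here, with no comparable step measured, only a small shift is expected, if any, perhaps toward a slightly higher number; the expected step of a 1.9-fold higher number from compound 1 to compound 3 (0.27 log units; within the scatter) is not clearly beyond the scatter. Compound 3 is therefore estimated at 30 nM, within a range from 8 nM to 120 nM.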

Compound 3, half-maximal effective concentration: 20 nM
Compound 3: the middle estimate sits 1.5-fold (0.18 log units) above what was measured, and the stated range covers the measured number.
By their numbers in this assay, from the lowest: compounds 2, 1 and 3 (each within the scatter of the next).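

In this assay, methyl in place of cyano on the aromatic carbon next to the ring sulfur gives a 1.3-fold higher number from compound 1 to compound 3 (0.10 log units; within the scatter) and so leaves the number unchanged within the scatter. On this background, the position keeps its number without the triple bond or the hydrogen-bond acceptor of the cyano group. Nothing available accounts for this result.

On these data alone, whether an amine, a carboxylic acid or a longer chain on this carbon would also hold the number remains open. So does how trifluoromethyl compares with methyl and cyano when the 2-methylphenyl group is kept.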